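Bromine Added to a Cytotoxic Glycoside Triazole

The compounds below may be only part of what the source reports. "The series", "measured", "known", "first", "only" and "open" are said of these compounds alone.

Compound 1, `CC(=O)OC[C@H]1O[C@H](OC[C@@H](Cn2cc(CN(c3nc(-c4ccccc4)no3)C3CCCCC3)nn2)OC(C)=O)C=C[C@@H]1OC(C)=O`, gives 28.6 ug/mL.
Compound 2, `C#CCOc1ccc(-c2noc(N(CC#C)C3CCCCC3)n2)cc1`, gives 101 ug/mL.

Both were tested in an ADME assay on RAW264.7 cells (Mus musculus) for cytotoxicity, read by MTT assay, with a stated time of 48 h; on this read-out lower numbers stand for higher toxicity in this test and higher numbers for lower toxicity in this test. Compound 1 stands at the lowest of the two numbers, meaning it is the more toxic of the pair; compound 2 gives a higher number, and the gap between them lies beyond the usual scatter. The two compounds differ in many places at once, so no single structural step can be read from them.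

Compound 3, `CC(=O)OC[C@H]1O[C@H](OC[C@@H](Cn2cc(CN(c3nc(-c4ccc(Br)cc4)no3)C3CCCCC3)nn2)OC(C)=O)C=C[C@@H]1OC(C)=O`, has not yet been measured. It differs from compound 1 in one place only: bromo in place of hydrogen on an aromatic carbon. Cut one bond further out, the change reads phenyl to 4-bromophenyl. Nothing measured here shows how such a change moves this read-out, so the step of a 1.3-fold lower number from compound 1 to compound 3 (0.11 log units; within the scatter) is expected to be small, within the scatter, with only a slight lean toward a lower number. Compound 3 is therefore estimated at 22 ug/mL, with a range from 10 ug/mL to 50 ug/mL.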

Compound 3, half-maximal cytotoxic concentration: 39.1 ug/mL
Estimate against measurement, compound 3: 1.8-fold (0.25 log units) below; the range from low to high includes it.
By their numbers in this assay, from the lowest: compounds 1 and 3 (each within the scatter of the next); then compound 2.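

In this assay, among the compounds shown here, bromo in place of hydrogen on the aromatic carbon para to a large group gives a 1.4-fold higher number from compound 1 to compound 3 (0.14 log units; within the scatter), the first comparison here in which only one place changes. Compound 1 and compound 3 therefore cannot be told apart in this test, and adding this one bromine atom to the phenyl ring leaves no readable mark on the cytotoxicity number. Nothing measured on these compounds bears on the reason for this result.

Still open, as far as these compounds go, is whether a different group at this same carbon, such as an amine, a carboxylic acid or a longer chain, would shift the number beyond the scatter. Also open, from the compounds shown here alone, is whether a smaller halogen, such as fluoro or chloro, would behave as bromo does here.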